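A few compounds are considered here, and "the series" means these few. Any claim that something is new, unique, unknown or untested is made for them only; others in the source may bear on it.

Three compounds share one core and differ only in the chain attached to the ester. In an assay for inhibition of Polyunsaturated fatty acid 5-lipoxygenase (Homo sapiens), read by HPLC, with a stated time of 10 min (a higher number here means a weaker inhibitor, a lower number a stronger inhibitor), compound 1 `C#CCCOC(=O)/C=C/c1ccc(OC(C)=O)c(OC(C)=O)c1` gives 1800 nM. Compound 2 `C#CCCCCCOC(=O)/C=C/c1ccc(OC(C)=O)c(OC(C)=O)c1` gives 470 nM in this assay. Compound 3 `C#CCCCCCCCCOC(=O)/C=C/c1ccc(OC(C)=O)c(OC(C)=O)c1` gives 180 nM, the lowest of the three numbers. The steps between them all run the same way: a 3.8-fold lower number from compound 1 to compound 2 (0.58 log units; beyond the scatter), a 10-fold lower number from compound 1 to compound 3 (1.00 log units; beyond the scatter) and a 2.6-fold lower number from compound 2 to compound 3 (0.42 log units; beyond the scatter). Each lengthening of the chain has brought a lower number.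

Compound 4 `CC(=O)Oc1ccc(/C=C/C(=O)OCCCCCCCCc2cnnn2CCCO)cc1OC(C)=O` takes the chain further but ends it differently: 1-(3-hydroxypropyl)-1H-1,2,3-triazol-5-yl in place of ethynyl on a saturated chain carbon, eight bonds along the chain from an oxygen next to a carbonyl group. The measured steps show that extending the chain beyond the ester lowers the number, yet none of them introduces a ring, a hydrogen-bond donor or hydrogen-bond acceptors, so the new end group has no precedent among these compounds. The expectation is a small further drop, a 1.3-fold lower number from compound 3 to compound 4 (0.11 log units; within the scatter), held with little confidence. Compound 4 is estimated at 140 nM, within a range from 50 nM to 500 nM.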

Compound 4, half-maximal inhibitory concentration: 200 nM
Compound 4: the middle estimate sits 1.4-fold (0.15 log units) below what was measured, within the range that was stated.
By their numbers in this assay, from the lowest: compounds 3 and 4 (each within the scatter of the next); then compound 2; then compound 1.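

In this assay, putting 1-(3-hydroxypropyl)-1H-1,2,3-triazol-5-yl in place of ethynyl gives a 1.1-fold higher number from compound 3 to compound 4 (0.05 log units; within the scatter) and so shows that this position, eight bonds along the chain from an oxygen next to a carbonyl group, can carry an aromatic ring, a hydrogen-bond donor and hydrogen-bond acceptors with no change beyond the scatter. Set against the shorter chain, the same end group gives a 2.4-fold lower number from compound 2 to compound 4 (0.37 log units; beyond the scatter) and so keeps a number well below that of compound 2. No measurement here bears on why the ethynyl and triazole ends read alike.

The compounds shown leave open whether the hydroxyl matters, as a plain propyl, an amine or a carboxylic acid on the triazole would test. They also leave open whether a longer chain before the triazole would lower the number further.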